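This account rests on a few compounds, and the source may have more. Where it says the series, first, only, none or still open, it means among the compounds named here.

Going by the values given here, compound 1 `c1ccc(C2CC(c3ccc4c(c3)OCCO4)=NN2c2ccccc2)cc1` is the weakest growth inhibitor among the three compounds measured so far. In a functional assay on WM 266-4 cells (Homo sapiens) for antiproliferative activity, read by MTT assay, with a stated time of 24 h (a higher number here means a weaker inhibitor of growth, a lower number a stronger inhibitor of growth), compound 1 gives 22400 nM, the highest of the three numbers. Compound 2 `Oc1ccccc1C1CC(c2ccc(Cl)c(Cl)c2)=NN1c1ccccc1` gives 1570 nM, and compound 3 `c1ccc(COc2cccc(C3CC(c4ccc5c(c4)OCCO5)=NN3c3ccccc3)c2)cc1` gives 870 nM. Compound 3 differs from compound 1 only by benzyloxy in place of hydrogen on an aromatic carbon, and that single change brought a 26-fold lower number from compound 1 to compound 3 (1.41 log units; beyond the scatter).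

Compound 4 `c1ccc(COc2ccc(C3CC(c4ccc5c(c4)OCCO5)=NN3c3ccccc3)cc2)cc1` has not yet been measured. It differs from compound 1 in one place: benzyloxy in place of hydrogen on an aromatic carbon. Among the compounds with values here, the only measured step that bears on this change is the one from compound 1 to compound 3, where the same benzyloxy group entered the same ring, though at a different place, and the number fell sharply. A drop of comparable direction is therefore expected here, though with less certainty about its size. The step from compound 1 to compound 4 in this assay is expected to be an 11-fold lower number from compound 1 to compound 4 (1.05 log units; beyond the scatter), giving an estimate for compound 4 of 2000 nM, within a range from 500 nM to 8000 nM.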

Compound 4, concentration for 50% growth inhibition: 1130 nM
Compound 4: middle estimate off by 1.8-fold (0.25 log units), on the high side; the range from low to high includes it.
By their numbers in this assay, from the lowest: compounds 3, 4 and 2 (each within the scatter of the next); then compound 1.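

In this assay, benzyloxy also gives a large drop at the place para to a large group, with a 20-fold lower number from compound 1 to compound 4 (1.30 log units; beyond the scatter). The strong gain seen with compound 3 is therefore not confined to one place on this ring: compound 3 and compound 4 carry the same group at different places, yet their numbers lie within the scatter of each other. Nothing available here explains why the group has this effect at either place.

The compounds shown leave open whether the whole benzyloxy group is needed, or whether a smaller methoxy group or a hydroxyl group at the same place would give a similar step. Also open, as far as these compounds go, is whether benzyloxy would bring a similar drop on the core of compound 2, which differs from compound 1 in more than one place.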